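This account rests on a few compounds, and the source may have more. Where it says the series, first, only, none or still open, it means among the compounds named here.

Going by the values given here, compound 2 `C/C=C(\C)C(=O)O[C@@H]1[C@@H]2OC[C@]3(C)[C@H](OC(C)=O)C[C@H](O)[C@@](C)([C@@H]23)[C@H]2CC(=O)O[C@H]3C[C@@H](c4ccoc4)C(C)=C3[C@]12C` carries the lower of the two numbers measured so far in a functional assay on HeLa S3 cells (Homo sapiens) for cytotoxicity, read by WST assay, with a stated time of 72 h (a higher number here means a weaker inhibitor, a lower number a stronger inhibitor), with compound 2 giving 100 nM. Compound 1 `C/C=C(\C)C(=O)O[C@H]1C[C@@H](OC(C)=O)[C@@]2(C)CO[C@H]3[C@@H](OC(=O)c4ccccc4)[C@@]4(C)C5=C(C)[C@H](c6ccoc6)C[C@@H]5OC(=O)C[C@@H]4[C@]1(C)[C@@H]32` sits far above it: in this assay compound 1 gives 29700 nM, a gap well beyond the usual scatter. Compound 3 `CC(=O)O[C@@H]1C[C@H](O)[C@@]2(C)[C@H]3[C@@H](OC[C@]13C)[C@@H](OC(=O)c1ccccc1)[C@@]1(C)C3=C(C)[C@H](c4ccoc4)C[C@@H]3OC(=O)C[C@@H]12` has not yet been measured. Its structure differs from that of compound 2 in a single place: phenyl in place of 1-methylprop-1-en-1-yl on a carbonyl carbon. Compound 1 also carries a benzoyloxy group, though it differs from compound 2 in other places as well, so no single step can be read from that pair. The expected step of a 4.0-fold higher number from compound 2 to compound 3 (0.60 log units; beyond the scatter) is a moderate rise in the number, with wide uncertainty in both directions. Compound 3 is therefore estimated at 400 nM in this assay, within a range from 60 nM to 4000 nM.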

Compound 3, half-maximal inhibitory concentration: 2400 nM
For compound 3 the middle estimate is 6.0-fold (0.78 log units) below the measured one; low and high end bracket the measured number.
By their numbers in this assay, from the lowest: compound 2; then compound 3; then compound 1.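

In this assay, phenyl in place of 1-methylprop-1-en-1-yl on a carbonyl carbon gives a 24-fold higher number from compound 2 to compound 3 (1.38 log units; beyond the scatter), so the number at this position depends strongly on which of these two groups the carbonyl carries. Compound 3 also isolates a second site: with benzoyloxy held constant, hydrogen in place of (1-methylprop-1-en-1-yl)carbonyl on an oxygen on a saturated carbon gives a 12-fold lower number from compound 1 to compound 3 (1.09 log units; beyond the scatter), so that change lowers the number. Nothing available here explains either step.

The compounds shown leave open how a smaller acetyl group, a longer saturated acyl chain or an acyl group bearing an amine would behave on the first site. They also leave open whether the second step would keep its size with (1-methylprop-1-en-1-yl)carbonyl, rather than benzoyl, on the first site.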